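Bromo to trifluoromethyl on the aromatic carbon

The compounds below may be only part of what the source reports. "The series", "measured", "known", "first", "only" and "open" are said of these compounds alone.

Working notes on the series. Three compounds have numbers in an assay on isolated protein for inhibition of Amine oxidase [flavin-containing] B (Homo sapiens), read by fluorescence and spectrophotometry, with a stated time of 20 min; a lower number here means a stronger inhibitor, a higher number a weaker inhibitor. The unsubstituted parent, compound 1 `O=c1[nH]c(SCc2ccccc2)nc2ccccc12`, gives 3030 nM. Compound 2 `O=c1[nH]c(SCc2ccc(F)cc2)nc2ccccc12` gives 566 nM, and compound 3 `O=c1[nH]c(SCc2ccc(Br)cc2)nc2ccccc12` gives 779 nM. Compound 3 thus stands second highest of the three numbers: its nearest neighbour is compound 2, from which it differs by a 1.4-fold higher number from compound 2 to compound 3 (0.14 log units; within the scatter), and its furthest is compound 1, from which it differs by a 3.9-fold lower number from compound 1 to compound 3 (0.59 log units; beyond the scatter).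

The next compound, compound 4 `O=c1[nH]c(SCc2ccc(C(F)(F)F)cc2)nc2ccccc12`, differs from compound 3 in one place: trifluoromethyl in place of bromo on an aromatic carbon. For the measured compounds named here, the steps that bear on this change are those from the parent to the two substituted compounds, a 5.4-fold lower number from compound 1 to compound 2 (0.73 log units; beyond the scatter) and a 3.9-fold lower number from compound 1 to compound 3 (0.59 log units; beyond the scatter), both modest and both in the same direction, together with the step between the two substituted compounds, a 1.4-fold higher number from compound 2 to compound 3 (0.14 log units; within the scatter), which lies within the scatter. Going by the values given here, nothing measured so far says how a trifluoromethyl group on this carbon behaves; only that two different groups there give numbers close to each other.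

The expectation for compound 4 is therefore a number near that of compound 3, with a step of a 1.0-fold lower number from compound 3 to compound 4 (0.02 log units; within the scatter) that is not expected to go beyond the scatter. In this assay compound 4 is estimated at 750 nM, within a range from 250 nM to 2300 nM.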

Compound 4, half-maximal inhibitory concentration: 700 nM
Compound 4: middle estimate off by 1.1-fold (0.03 log units), on the high side; measured number inside the range.
By their numbers in this assay, from the lowest: compounds 2, 4 and 3 (each within the scatter of the next); then compound 1.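

In this assay, a third group on this aromatic carbon, para to a large group, gives a number that cannot be separated from the earlier two (see a 1.1-fold lower number from compound 3 to compound 4 (0.05 log units; within the scatter) and a 1.2-fold higher number from compound 2 to compound 4 (0.09 log units; within the scatter)). Trifluoromethyl brings 4 heavy atoms where bromo brings 1, yet the steps among the three substituted compounds all lie within the scatter, so this change shows no readable effect here, and the step from the parent persists (see a 4.3-fold lower number from compound 1 to compound 4 (0.64 log units; beyond the scatter)), which makes compounds 2, 3 and 4 a group set apart from compound 1 by modest steps beyond the scatter. No measurement on hand bears on what lies behind this flat response.

Open, going by these compounds, is whether the same response holds for an amine, a carboxylic acid or a longer chain such as butyl on this carbon, any of which might leave the group of three or stay with it. Also open, on these data alone, is whether a methoxy group or a nitrile would give a number near these three or one nearer to compound 1.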